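This account rests on a few compounds, and the source may have more. Where it says the series, first, only, none or still open, it means among the compounds named here.

In an ADME assay on MT4 cells (Homo sapiens) for cytotoxicity, read by MTT assay (on this read-out lower numbers stand for higher toxicity in this test and higher numbers for lower toxicity in this test), the three measured compounds lie close together. Compound 1 `Cc1cc(C)cc(S(=O)(=O)c2c(C(=O)NC(C)C(=O)NCCn3c(C)cnc3[N+](=O)[O-])[nH]c3ccc(Cl)cc23)c1` gives 16000 nM, compound 2 `Cc1cc(C)cc(S(=O)(=O)c2c(C(=O)NC(C)C(=O)NC(C)c3ccccc3)[nH]c3ccc(Cl)cc23)c1` gives 21700 nM and compound 3 `Cc1cc(C)cc(S(=O)(=O)c2c(C(=O)NC(C)C(=O)NC(C)c3ccccc3F)[nH]c3ccc(Cl)cc23)c1` gives 15200 nM. Compound 3 therefore cannot be separated from the other two, with a 1.1-fold lower number from compound 1 to compound 3 (0.02 log units; within the scatter) and a 1.4-fold lower number from compound 2 to compound 3 (0.15 log units; within the scatter).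

Compound 4 `Cc1cc(C)cc(S(=O)(=O)c2c(C(=O)NC(C)C(=O)NCc3ccccc3F)[nH]c3ccc(Cl)cc23)c1` differs from compound 3 by hydrogen in place of methyl on a saturated chain carbon bound to an amide-type nitrogen and an aromatic carbon. In words, this is hydrogen in place of methyl on a saturated chain carbon bound to an amide-type nitrogen and an aromatic carbon, so 1-(2-fluorophenyl)ethyl becomes 2-fluorobenzyl.

Among the measured compounds shown here, no measured step makes this exact change, so the evidence is indirect. The fluoro exchange gave a 1.4-fold lower number from compound 2 to compound 3 (0.15 log units; within the scatter). Larger exchanges of the whole group on the amide-type nitrogen gave a 1.4-fold higher number from compound 1 to compound 2 (0.13 log units; within the scatter) and a 1.1-fold lower number from compound 1 to compound 3 (0.02 log units; within the scatter). All three steps stay within the scatter, and these three compounds alone cannot show how far that holds for a smaller change at the saturated chain carbon. No step beyond the scatter is expected in this assay, and no direction is favoured.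

The expected step is a 1.1-fold higher number from compound 3 to compound 4 (0.02 log units; within the scatter). Compound 4 is estimated at 16000 nM, with an expected range of 9000 nM to 29000 nM.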

Compound 4, half-maximal cytotoxic concentration: 23300 nM
Estimate against measurement, compound 4: 1.5-fold (0.16 log units) below; the range from low to high includes it.
By their numbers in this assay, from the lowest: compounds 3, 1, 2 and 4 (each within the scatter of the next).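

In this assay, among the compounds shown here, the first direct reading of hydrogen in place of methyl on a saturated chain carbon bound to an amide-type nitrogen and an aromatic carbon is a 1.5-fold higher number from compound 3 to compound 4 (0.19 log units; within the scatter), so this change of 1-(2-fluorophenyl)ethyl to 2-fluorobenzyl stays within the scatter. The 2-fluorobenzyl group also cannot be separated from 1-phenylethyl on the amide-type nitrogen, with a 1.1-fold higher number from compound 2 to compound 4 (0.03 log units; within the scatter), or from the larger group with the five-membered aromatic ring, with a 1.5-fold higher number from compound 1 to compound 4 (0.16 log units; within the scatter), so all the variations at this end of the molecule shown so far leave the read-out within one band, and the methyl is not needed to stay in it. Nothing at hand gives a reason for these readings.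

Still open, as far as these compounds go, is whether any group at this position leaves that band, for example an ethyl in place of the methyl on the saturated chain carbon, or a primary amine or a carboxylic acid on the aromatic ring. From the compounds shown here alone, the plain benzyl group, without fluoro, would complete the set of methyl and fluoro exchanges, and changes on the shared core remain untested by these compounds.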